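From 3-hydroxypiperidin-1-yl to 4-hydroxypiperidin-1-yl in compound 2

The source may hold more compounds than are shown below. What is called first, only, known or untested is meant among the compounds shown, and "the series" means these compounds.

In a functional assay on HL-60 cells (Homo sapiens) for cytotoxicity, read by MTT assay, with a stated time of 72 h (on this read-out higher numbers stand for weaker inhibition and lower numbers for stronger inhibition), compound 1 `Cc1ccc(S(=O)(=O)c2nc3ccccc3nc2N2CCCC2)cc1` gives 9720 nM, compound 2 `Cc1ccc(S(=O)(=O)c2nc3ccccc3nc2N2CCCC(O)C2)cc1` gives 6080 nM and compound 3 `COc1ccc(S(=O)(=O)c2nc3ccccc3nc2N2CCCC(O)C2)cc1` gives 3050 nM. Compound 2 thus stands within the scatter of both of the compounds joined to it by a single change. Those changes are a 1.6-fold lower number from compound 1 to compound 2 (0.20 log units; within the scatter), with 3-hydroxypiperidin-1-yl in place of pyrrolidin-1-yl, and a 2.0-fold lower number from compound 2 to compound 3 (0.30 log units; within the scatter), with methoxy in place of methyl.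

Compound 4 `Cc1ccc(S(=O)(=O)c2nc3ccccc3nc2N2CCC(O)CC2)cc1` differs from compound 2 in one place: 4-hydroxypiperidin-1-yl in place of 3-hydroxypiperidin-1-yl on an aromatic carbon, with 4-hydroxypiperidin-1-yl in place of 3-hydroxypiperidin-1-yl on an aromatic carbon next to the ring nitrogen. For the measured compounds named here, no measured pair shifts the hydroxy group alone. The first step touches the same place only loosely, and the second concerns a different group. Starting from compound 2 at 6080 nM, no step beyond the scatter is expected in either direction in this assay. The expected result is a 1.0-fold lower number from compound 2 to compound 4 (0.01 log units; within the scatter). Compound 4 is estimated at 6000 nM, with an expected range of 2500 nM to 14000 nM.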

Compound 4, half-maximal inhibitory concentration: 4050 nM
The estimate for compound 4 lay 1.5-fold (0.17 log units) above the measured number, within the range that was stated.
By their numbers in this assay, from the lowest: compounds 3, 4, 2 and 1 (each within the scatter of the next, the first and the last beyond it).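

In this assay, for the compounds shown here, the only pair that shifts the hydroxy group alone gives a 1.5-fold lower number from compound 2 to compound 4 (0.18 log units; within the scatter), so this read-out does not tell 3-hydroxypiperidin-1-yl and 4-hydroxypiperidin-1-yl apart at this position. Measured against pyrrolidin-1-yl, however, 4-hydroxypiperidin-1-yl gives a 2.4-fold lower number from compound 1 to compound 4 (0.38 log units; beyond the scatter), the only step at this position shown to lie beyond the scatter, and a modest one. No supporting data bear on this result.

The compounds shown leave open what a piperidin-1-yl group without the hydroxy, or a piperazine carrying a second amine, would give at this position, so the contributions of the hydroxy group and the ring cannot be separated. On these data alone, it also remains open whether methoxy in place of methyl would give a similar step alongside 4-hydroxypiperidin-1-yl.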